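Removing a methyl from the aromatic ring of compound 2

The source may report more compounds than this note shows. Statements on the series, on what has been measured and on what is new or still open speak of the compounds shown alone.

Measured so far:
Compound 1 `N/C(=N\NC(=S)N1CCCCC1)c1ccccn1` — 86.5%
Compound 2 `Cc1cccc(/C(N)=N/NC(=S)N2CCCC2)n1` — 51.3%

Of the compounds shown here, two have been tested in a functional assay on A-375 cells (Homo sapiens) for cytotoxicity, read by MTT assay, with a stated time of 72 h, tested at 3 uM; a higher number here means more inhibition of growth at the concentration tested, a lower number less inhibition of growth. Compound 1 `N/C(=N\NC(=S)N1CCCCC1)c1ccccn1` gives 86.5%. Compound 2 `Cc1cccc(/C(N)=N/NC(=S)N2CCCC2)n1` gives 51.3%. Compound 2 stands lowest of the two numbers, and its nearest neighbour, compound 1, sits a good deal higher, a gap beyond the scatter. Compound 1 and compound 2 differ in more than one place, so their two values show only that much and no single change can be read from them.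

Compound 3 `N/C(=N\NC(=S)N1CCCC1)c1ccccn1` has not yet been measured. Compared with compound 2 the change is hydrogen in place of methyl on an aromatic carbon: the methyl leaves from the position next to the ring nitrogen, meta to a large group, and compound 3 thereby shares its unmethylated ring with compound 1 while keeping the five-membered saturated ring of compound 2. Because compound 1, which also lacks the methyl, gives 86.5%, an increase in this assay is expected, of a size about a number 16.7 percentage points higher from compound 2 to compound 3 (beyond the scatter), though the ring-size difference leaves this uncertain. Compound 3 is therefore estimated at 68%, within a range from 45% to 88%.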

Compound 3, percent growth inhibition at one concentration: 80%
The estimate for compound 3 lay 12 percentage points below the measured number; low and high end bracket the measured number.
By their numbers in this assay, from the lowest: compound 2; then compounds 3 and 1 (each within the scatter of the next).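

In this assay, within the data shown here, the first comparison that isolates this position shows that hydrogen in place of methyl on the aromatic carbon next to the ring nitrogen gives a number 28.7 percentage points higher from compound 2 to compound 3 (beyond the scatter), so the methyl here goes with less inhibition of growth at the concentration tested, at least with pyrrolidin-1-yl on the thiocarbonyl carbon. The second step, pyrrolidin-1-yl in place of piperidin-1-yl on the thiocarbonyl carbon, gives a number 6.5 percentage points lower from compound 1 to compound 3 (within the scatter), so this change of saturated ring does not separate the two unmethylated compounds in this assay, and the gap between compound 1 and compound 2 tracks the methyl rather than the ring. Nothing available explains why the methyl matters at this position.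

The compounds shown leave open whether the methyl step would recur with piperidin-1-yl on the thiocarbonyl carbon, and how a chlorine atom or a methoxy group on the same aromatic carbon would compare with hydrogen and methyl. They also leave open whether a morpholin-4-yl or an open-chain dimethylamino group on the thiocarbonyl carbon would fit alongside the two saturated rings.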